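Moving the ring fluorine: from compound 2 to compound 3

The source may hold more compounds than are shown below. What is called first, only, known or untested is meant among the compounds shown, and "the series" means these compounds.

Measured so far:
compound 1, `CCC(C(=O)N1CCN(c2cccc(F)c2)CC1)N1C(=O)CCC1=O`, 75%
compound 2, `CC(C(=O)N1CCN(c2ccccc2F)CC1)N1C(=O)CCC1=O`, 50%

In a functional assay on the whole organism (strain Swiss) with Mus musculus as the target, in the maximal electroshock model, with a stated time of 1 h, at a dose of 300 mg/kg by the intraperitoneal route (on this read-out lower numbers stand for a weaker effect and higher numbers for a stronger effect at the one dose given), compound 1 gives 75%, while compound 2 gives 50%. Compound 2 thus stands lowest of the two numbers; its nearest neighbour is compound 1, and the gap between them lies beyond the usual scatter.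

Compound 3, `CC(C(=O)N1CCN(c2cccc(F)c2)CC1)N1C(=O)CCC1=O`, has not yet been measured. It differs from compound 2 in one place: 3-fluorophenyl in place of 2-fluorophenyl on an amine nitrogen in a ring. For the measured compounds named here, no pair of measured compounds differs in this place alone, so the worth of this change is not yet known from a measured step. Compound 1 also carries 3-fluorophenyl and gives 75%, but it differs from compound 3 elsewhere as well, so it is only a loose guide.

The expected step of a number 12 percentage points higher from compound 2 to compound 3 (beyond the scatter) is modest and upward, though an outcome within the scatter would not surprise. Compound 3 is therefore estimated at 62%, with a range from 35% to 90%.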

Compound 3, a percentage reported as activity, at one dose (the size of the read-out at that dose, not a potency): 75%
For compound 3 the middle estimate is 13 percentage points below the measured one, and the stated range covers the measured number.
By their numbers in this assay, from the lowest: compound 2; then compounds 1 and 3 (each within the scatter of the next).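

In this assay, the place of the ring fluorine now has a measured worth: 3-fluorophenyl in place of 2-fluorophenyl on an amine nitrogen in a ring gives a number 25 percentage points higher from compound 2 to compound 3 (beyond the scatter). With 3-fluorophenyl held constant, hydrogen in place of methyl on a saturated chain carbon, two bonds along the chain from an amide-type nitrogen in a ring and a carbonyl carbon, gives no change at the digits printed from compound 1 to compound 3 (within the scatter), so this chain change leaves the read-out unmoved at this one dose. Nothing in the available data accounts for either result.

Open, going by these compounds, is how unsubstituted phenyl, 4-fluorophenyl or 3-chlorophenyl would read at this place on the ring nitrogen. Also open, on these data alone, is whether the fluorine step holds on the chain of compound 1, and whether a propyl chain would read the same.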